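A few compounds are considered here, and "the series" means these few. Any claim that something is new, unique, unknown or untested is made for them only; others in the source may bear on it.

Three compounds share one core and differ only in a single group on an aromatic carbon. In a functional assay on cells for antagonist activity at prostaglandin D2 receptor 2 (Homo sapiens), read by flow cytometry, with a stated time of 10 min (on this read-out lower numbers stand for stronger inhibition and higher numbers for weaker inhibition), compound 1, `CS(=O)(=O)c1ccc(F)c(C#Cc2cc(Cl)ccc2OCC(=O)O)c1`, gives 95 nM. Compound 2, `Cc1ccc(S(C)(=O)=O)cc1C#Cc1cc(Cl)ccc1OCC(=O)O`, gives 64 nM, and compound 3, `CC(C)c1ccc(S(C)(=O)=O)cc1C#Cc1cc(Cl)ccc1OCC(=O)O`, gives 360 nM. Compound 2 has the lowest of the three numbers: the step of a 1.5-fold lower number from compound 1 to compound 2 (0.17 log units; within the scatter) leaves it within the scatter of compound 1, while a 5.6-fold higher number from compound 2 to compound 3 (0.75 log units; beyond the scatter) sets compound 3 clearly apart, as does a 3.8-fold higher number from compound 1 to compound 3 (0.58 log units; beyond the scatter).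

Compound 4, `Cc1ccc(S(=O)(=O)N(C)C(C)C)cc1C#Cc1cc(Cl)ccc1OCC(=O)O`, differs from compound 2 at the sulfonyl group: isopropyl(methyl)amino in place of methyl on a sulfonyl sulfur. For the measured compounds named here, no measured step touches the sulfonyl sulfur; every step so far swaps a group on an aromatic carbon, so nothing measured bears directly on this change. Going by the values given here, the only loose guide is that isopropyl in place of fluoro or methyl on the aromatic carbon raised the number in compound 3, seen in a 3.8-fold higher number from compound 1 to compound 3 (0.58 log units; beyond the scatter) and a 5.6-fold higher number from compound 2 to compound 3 (0.75 log units; beyond the scatter), and compound 4 likewise gains an isopropyl, though at a different place. The expectation for compound 4 in this assay is therefore a modest rise with wide uncertainty, estimated as a 2.3-fold higher number from compound 2 to compound 4 (0.37 log units; beyond the scatter). Compound 4 is expected to give about 150 nM, within a range from 40 nM to 600 nM.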

Compound 4, half-maximal inhibitory concentration: 140 nM
Compound 4: middle estimate off by 1.1-fold (0.03 log units), on the high side, and the stated range covers the measured number.
By their numbers in this assay, from the lowest: compounds 2, 1 and 4 (each within the scatter of the next, the first and the last beyond it); then compound 3.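

For the compounds shown here, compound 4 gives the first reading at the sulfonyl sulfur, which the earlier steps, all on an aromatic carbon, never touched. In this assay, isopropyl(methyl)amino in place of methyl on that sulfur gives a 2.2-fold higher number from compound 2 to compound 4 (0.34 log units; beyond the scatter), so a group of 5 heavy atoms replacing a single carbon costs only a modest step, and the methylsulfonyl group can give way to isopropyl(methyl)sulfamoyl with inhibition still measurable in the same nanomolar range. Nothing available explains why the number rises, so the size of this step stands as an observation without a cause.

With only one sulfamoyl group shown, it stays unclear whether the rise belongs to the nitrogen itself or to the isopropyl and methyl groups it carries; a plain amino group, a dimethylamino group or a morpholine on the sulfonyl sulfur would help to tell these apart. Going by these compounds, it is also open whether isopropyl(methyl)amino on the sulfonyl sulfur would give a step of similar size alongside fluoro or isopropyl, rather than methyl, on the aromatic carbon.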